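The compounds below may be only part of what the source reports. "The series", "measured", "known", "first", "only" and "open" are said of these compounds alone.

Measured compounds:
- compound 1, `CCCCC(C)(C)[C@H](O)/C=C/C1C2CCC(O2)C1C/C=C\CCCC(=O)O` — in a functional assay (plasma) for inhibition, with Homo sapiens as the target (on this read-out higher numbers stand for weaker inhibition and lower numbers for stronger inhibition), compound 1 gives 1100 nM
- compound 2, `O=C(O)CCC/C=C\CC1C2CCC(O2)C1/C=C/[C@@H](O)CCc1ccccc1` — in this assay compound 2 gives 1200 nM
- compound 3, `C[C@@H](c1ccc(O)cc1)[C@H](O)/C=C/C1C2CCC(O2)C1C/C=C\CCCC(=O)O` — in this assay compound 3 gives 240 nM

Compound 3 stands lowest of the three; the step of a 4.6-fold lower number from compound 1 to compound 3 (0.66 log units; beyond the scatter) and the step of a 5.0-fold lower number from compound 2 to compound 3 (0.70 log units; beyond the scatter) both lie beyond the scatter, while the step of a 1.1-fold higher number from compound 1 to compound 2 (0.04 log units; within the scatter) does not. Compound 4, `C[C@@H](c1ccc(O)c(I)c1)[C@H](O)/C=C/C1C2CCC(O2)C1C/C=C\CCCC(=O)O`, differs from compound 3 in one place: iodo in place of hydrogen on an aromatic carbon, on an aromatic carbon of a six-membered aromatic ring of carbon only, ortho to a hydroxy group and meta to a large group. Going by the values given here, none of the measured steps changes a substituent on this ring; they all swap the whole group on the saturated chain carbon, so no measured step bears directly on this change. Among the compounds with values here, they show only that the 4-hydroxyphenyl-bearing group gives the lowest number. Compound 4 is therefore expected to remain close to compound 3 in this assay, with the step of a 1.2-fold lower number from compound 3 to compound 4 (0.08 log units; within the scatter) expected to fall within the scatter. Compound 4 is estimated at 200 nM, in the range 70 nM to 700 nM.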

Compound 4, half-maximal inhibitory concentration: 930 nM
For compound 4 the middle estimate is 4.7-fold (0.67 log units) below the measured one, and the stated range ends below it.
By their numbers in this assay, from the lowest: compound 3; then compounds 4, 1 and 2 (each within the scatter of the next).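

In this assay, putting iodo in place of hydrogen on the aromatic carbon ortho to a hydroxy group is no silent change: the step is a 3.9-fold higher number from compound 3 to compound 4 (0.59 log units; beyond the scatter), and it lies beyond the scatter. Going by these compounds alone, the earlier compounds showed only that the 4-hydroxyphenyl-bearing group stood apart from the other two groups, and this single atom removes that separation, since a 1.3-fold lower number from compound 2 to compound 4 (0.11 log units; within the scatter) and a 1.2-fold lower number from compound 1 to compound 4 (0.07 log units; within the scatter) both lie within the scatter. No measurement shown here accounts for this result.

Iodo is the only group shown at this position, so it remains open whether fluoro, chloro, methyl or an amine there would stay close to compound 3. From the compounds shown here alone, it is also open whether the 3-iodophenyl group without the hydroxy group would give a similar number.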